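Ecdysone receptor agonists: chain lengthening in two hydrazide cores

A few compounds are considered here, and "the series" means these few. Any claim that something is new, unique, unknown or untested is made for them only; others in the source may bear on it.

Measured compounds:
compound 1, `CCc1ccc(C(=O)NN(C(=O)c2ccccc2Cl)C(C)(C)C)cc1`: 5.75 nM
compound 2, `CC(C)c1ccc(C(=O)NN(C(=O)c2ccccc2Cl)C(C)(C)C)cc1`: 24.6 nM
compound 3, `CCCCC(=O)NN(C(=O)c1cc(C)cc(C)c1)C(C)(C)C`: 1860 nM

In an assay on cells for agonist activity at ecdysone receptor (Bombyx mori), read by a luciferase reporter, with a stated time of 24 h (a higher number here means that more compound is needed for the effect, a lower number that less compound is needed), compound 1 gives 5.75 nM. Compound 2 carries methyl in place of hydrogen on a saturated chain carbon bound to an aromatic carbon and a saturated chain carbon and in this assay gives 24.6 nM, so that a 4.3-fold higher number from compound 1 to compound 2 (0.63 log units; beyond the scatter). Compound 3 is built on a different core; the difference between the two cores is not broken down here. In this assay compound 3 gives 1860 nM, the highest number of the three, far beyond the scatter from both compound 1 and compound 2.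

Compound 4, `CCCCCC(=O)NN(C(=O)c1cc(C)cc(C)c1)C(C)(C)C`, is not yet measured. It differs from compound 3 by methyl in place of hydrogen on a saturated chain carbon, four bonds along the chain from a carbonyl carbon. This is the same kind of change as that from compound 1 to compound 2, but not the same: there the place was on a saturated chain carbon bound to an aromatic carbon and a saturated chain carbon, here it is on a saturated chain carbon, four bonds along the chain from a carbonyl carbon, and the core differs as well. Going by the values given here, the only measured step of this kind is a 4.3-fold higher number from compound 1 to compound 2 (0.63 log units; beyond the scatter), and it is the sole basis for expecting the direction of the step from compound 3 to compound 4 to be the same. Given the different place and core, a smaller step than that seen is expected, a 1.5-fold higher number from compound 3 to compound 4 (0.18 log units; within the scatter), with wide uncertainty. Compound 4 is estimated at 2800 nM in this assay, between 900 nM and 9000 nM.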

Compound 4, half-maximal effective concentration: 79.4 nM
Estimate against measurement, compound 4: 35-fold (1.55 log units) above; measured number below the stated range.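

In this assay, the new step is a 23-fold lower number from compound 3 to compound 4 (1.37 log units; beyond the scatter), so on the core of compound 3 the added methyl lowers the number, whereas on the core of compound 1 it raises it. Within this series, the effect of this change does not carry from one core to the other in either direction or size: the same change on two cores in this assay, a 4.3-fold higher number (0.63 log units; beyond the scatter) from compound 1 to compound 2 and a 23-fold lower number (1.37 log units; beyond the scatter) from compound 3 to compound 4, 100-fold (2.00 log units) apart, beyond the scatter of two such steps

This does not show that the core alone sets the outcome, since the place differs as well: a saturated chain carbon bound to an aromatic carbon and a saturated chain carbon in the first step, and a saturated chain carbon four bonds along the chain from a carbonyl carbon in the second, and the two pairs cannot separate core from place or give a cause for the reversal.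

Still open, as far as these compounds go, is whether a longer chain on the core of compound 4 would lower the number further, level off or raise it again, as one step gives no trend along the chain. Also open, from the compounds shown here alone, is how a chain ending in a hydroxyl group or an amine would read in this assay, and whether the same methyl placed four bonds along a chain on the core of compound 1 would follow compound 4 or compound 2.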